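Methyl on the linking ring: from compound 3 to compound 4

The source may report more compounds than this note shows. Statements on the series, on what has been measured and on what is new or still open speak of the compounds shown alone.

The three measured compounds share a core that carries a substituted phenyl on one arm; compound 1 `Cc1ccccc1-c1cccc(COc2ccc(S(=O)(=O)CC(=O)O)cc2)c1`, compound 2 `O=C(O)CS(=O)(=O)c1ccc(OCc2cccc(-c3ccccc3)c2)cc1` and compound 3 `Cc1noc(C)c1-c1cccc(COc2ccc(S(=O)(=O)CC(=O)O)cc2)c1` differ only in that arm. In a functional assay on CHO cells for agonist activity at Free fatty acid receptor 1 (Homo sapiens), read by FLIPR and calcium flux (a lower number here means that less compound is needed, a higher number that more compound is needed for the effect), compound 1 gives 46.8 nM, compound 2 gives 288 nM, and compound 3 gives 269 nM. The cores of compound 2 and compound 3 differ by 3,5-dimethyl-1,2-oxazol-4-yl in place of phenyl on an aromatic carbon, and this gives a 1.1-fold lower number from compound 2 to compound 3 (0.03 log units; within the scatter). The change methyl in place of hydrogen on an aromatic carbon gives a 6.2-fold lower number from compound 2 to compound 1 (0.79 log units; beyond the scatter), and a 5.7-fold higher number from compound 1 to compound 3 (0.76 log units; beyond the scatter) separates compound 1 from compound 3.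

Compound 4 `Cc1ccc(-c2c(C)noc2C)cc1COc1ccc(S(=O)(=O)CC(=O)O)cc1` is unmeasured; it differs from compound 3 by methyl in place of hydrogen on an aromatic carbon. This is the same kind of change as from compound 2 to compound 1, not the same: the place is again ortho to a large group, but in compound 4 it is also para to a 3,5-dimethyl-1,2-oxazol-4-yl group, whereas in compound 1 it is not. Among the compounds with values here, the step from compound 3 to compound 4 in this assay is expected to be a 3.8-fold lower number from compound 3 to compound 4 (0.58 log units; beyond the scatter), resting on the single earlier step of a 6.2-fold lower number from compound 2 to compound 1 (0.79 log units; beyond the scatter), with a wider range because the place differs. Compound 4 is thus estimated at 70 nM in this assay.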

Compound 4, half-maximal effective concentration: 427 nM
Compound 4: the middle estimate sits 6.1-fold (0.79 log units) below what was measured; measured number above the stated range.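

In this assay, methyl in place of hydrogen on an aromatic carbon gives a 1.6-fold higher number from compound 3 to compound 4 (0.20 log units; within the scatter), so the lower number seen on the earlier core does not reappear here. Within the data shown here, the change therefore does not carry over between these two cores as a fixed step: the same change on two cores in this assay, a 6.2-fold lower number (0.79 log units; beyond the scatter) from compound 2 to compound 1 and a 1.6-fold higher number (0.20 log units; within the scatter) from compound 3 to compound 4, 9.8-fold (0.99 log units) apart, beyond the scatter of two such steps With only one pair on each core, this does not show whether the place of the methyl, ortho to a large group and para to a 3,5-dimethyl-1,2-oxazol-4-yl group in compound 4, or the rest of the core accounts for the gap.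

Still open, from the compounds shown here alone, is how a methyl at this place behaves with the phenyl arm of compound 2. Also open, going by these compounds, is whether chlorine, methoxy or ethyl there would give a step like that of methyl.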